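Cyclohexyl for Butyl on the Chain of Compound 3

The source may hold more compounds than are shown below. What is called first, only, known or untested is meant among the compounds shown, and "the series" means these compounds.

Measured compounds:
compound 1 `CCCCCc1nc(N)n(CC(=O)Nc2ccccc2)c1-c1ccccc1Br` — 40600 nM
compound 2 `Cc1ccc(Cc2nc(N)n(CC(=O)Nc3ccccc3)c2-c2ccccc2Br)cc1` — 9200 nM
compound 3 `CCCCCc1nc(N)n(CC(=O)Nc2ccc(C)cc2)c1-c1ccccc1Br` — 5600 nM

The three compounds share one core and were tested in a functional assay on MIA PaCa-2 cells (Homo sapiens) for antiproliferative activity, read by MTT assay, with a stated time of 48 h; a lower number here means a stronger inhibitor, a higher number a weaker inhibitor. Compound 1 gives 40600 nM and is the weakest of the set. Compound 2 gives 9200 nM, and compound 3 gives 5600 nM. Compound 3 has the lowest number of the three, though its gap to compound 2 lies within the scatter, while its gap to compound 1 is beyond it.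

Compound 4 `Cc1ccc(NC(=O)Cn2c(N)nc(CC3CCCCC3)c2-c2ccccc2Br)cc1` has not yet been measured. It differs from compound 3 in one place: cyclohexyl in place of butyl on a saturated chain carbon bound to an aromatic carbon.

Among the compounds with values here, the step that bears most on this change is the one from compound 1 to compound 2, in which a ring group also replaced the butyl at this position: a 4.4-fold lower number from compound 1 to compound 2 (0.64 log units; beyond the scatter). The other step, a 7.3-fold lower number from compound 1 to compound 3 (0.86 log units; beyond the scatter), sits elsewhere in the molecule and was already made in compound 3. Within the data shown here, no measured step shows a non-aromatic ring at this place, so the expectation carries real uncertainty. On the strength of the ring-for-butyl step, compound 4 is expected to show a 2.2-fold lower number from compound 3 to compound 4 (0.35 log units; beyond the scatter).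

Compound 4 is therefore estimated at 2500 nM, with a range from 800 nM to 8000 nM.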

Compound 4, half-maximal inhibitory concentration: 48800 nM
Compound 4: middle estimate off by 20-fold (1.29 log units), on the low side; the whole stated range lies below it.
By their numbers in this assay, from the lowest: compounds 3 and 2 (each within the scatter of the next); then compounds 1 and 4 (each within the scatter of the next).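

In this assay, replacing butyl with cyclohexyl on a saturated chain carbon bound to an aromatic carbon gives an 8.7-fold higher number from compound 3 to compound 4 (0.94 log units; beyond the scatter), so a ring at this place does not in itself bring the number down. The earlier ring-for-butyl step, a 4.4-fold lower number from compound 1 to compound 2 (0.64 log units; beyond the scatter), ran the opposite way, which shows that the outcome here depends on more than the presence of a ring, although that step has 4-methylphenyl as its ring group and lacks the methyl carried by compound 4. Nothing measured here explains the opposite directions of the two steps.

The compounds shown cannot separate the kind of ring from the effect of that methyl, and it remains open whether the gain seen in a 7.3-fold lower number from compound 1 to compound 3 (0.86 log units; beyond the scatter) would also appear with cyclohexyl at this position. Also open, as far as these compounds go, is how a plain phenyl, a smaller cyclopentyl or a longer chain such as hexyl would behave here, which would show whether the loss follows the non-aromatic ring or the size of the group.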